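The compounds below may be only part of what the source reports. "The series", "measured", "known", "first", "only" and "open" are said of these compounds alone.

In a functional assay on NCI/ADR-RES cells (Homo sapiens) for inhibition, read by sulforhodamine B assay, with a stated time of 48 h (on this read-out higher numbers stand for weaker inhibition of growth and lower numbers for stronger inhibition of growth), compound 1 `S=C(N/N=C/c1cccs1)Nc1cccc2ccccc12` gives 6600 nM and compound 2 `Cc1ccc(NC(=S)N/N=C/c2cccs2)cc1` gives 4800 nM so that these two numbers sit within the usual scatter of each other. Compound 3 `C=CCNC(=S)N/N=C/c1cccs1` gives only a limit of > 100000 nM in this measurement. Compound 4 `S=C(N/N=C/c1cccs1)Nc1ccc(Br)cc1` is still unmeasured and has bromo in place of methyl on an aromatic carbon of compound 2 (bromo in place of methyl on an aromatic carbon). Within the data shown here, no measured pair shows this change directly. Compound 2 at 4800 nM keeps within the scatter of compound 1 at 6600 nM despite their different aromatic groups, so no shift beyond the scatter is expected in either direction. The expected step (a 1.1-fold lower number from compound 2 to compound 4 (0.03 log units; within the scatter)) is small. The estimated value for compound 4 is 4500 nM within a range of 1800 nM to 11000 nM in this assay.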

Compound 4, concentration for 50% growth inhibition: 1700 nM
Compound 4: middle estimate off by 2.6-fold (0.42 log units), on the high side, and the stated range ends above it.
By their numbers in this assay, from the lowest: compound 4; then compounds 2 and 1 (each within the scatter of the next). At a limit, above all of these: compound 3.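

In this assay, bromo in place of methyl on an aromatic carbon, para to a large group, gives a 2.8-fold lower number from compound 2 to compound 4 (0.45 log units; beyond the scatter). Among these compounds, this is the first sign that growth inhibition responds to the group held at this position, since no earlier pair isolated a change there. Nothing measured among these compounds offers a cause for this step. From the compounds shown here alone, it remains open whether chloro, methoxy or an amine at this place would track bromo or methyl. Going by these compounds, it is equally open whether bromo on another carbon of the ring would give a similar number.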